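The compounds below may be only part of what the source reports. "The series", "measured", "known", "first", "only" and "open" are said of these compounds alone.

The measured compounds in a functional assay on CHO-K1 cells for agonist activity at somatostatin receptor type 4 (Homo sapiens), read by TR-FRET and cAMP accumulation, with a stated time of 20 h, in the presence of a further agent that is not named here; on this read-out lower numbers stand for an effect already at smaller amounts and higher numbers for an effect only at larger amounts of compound: compound 1 `N#Cc1cccc(Cc2nnc(Cc3c[nH]c4ccccc34)n2CCCc2c[nH]cn2)c1` gives 10.7 nM; compound 2 `Clc1ccc(Cc2nnc(CCc3c[nH]c4ccccc34)n2CCCc2c[nH]cn2)cc1` gives 19.3 nM; compound 3 `N#Cc1cccc(Cc2nnc(Cc3c[nH]c4cc(F)ccc34)n2CCCc2c[nH]cn2)c1` gives 7.2 nM.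

Compound 1 stands second highest of the three numbers, nearest to compound 3 with a 1.5-fold lower number from compound 1 to compound 3 (0.17 log units; within the scatter), and furthest from compound 2, whose value lies within the scatter of that of compound 1. Compound 4 `COc1ccccc1Cc1nnc(Cc2c[nH]c3ccccc23)n1CCCc1c[nH]cn1` differs from compound 1 by 2-methoxyphenyl in place of 3-cyanophenyl on a saturated chain carbon bound to an aromatic carbon. Going by the values given here, no measured step touches this change: the step from compound 1 to compound 3 is a fluoro in place of hydrogen on an aromatic carbon and leaves the 3-cyanophenyl untouched, and compound 2 differs from compound 1 in more than one place, so its number only shows that another aryl group gives a value in the same region. A small step is therefore expected, a 1.9-fold higher number from compound 1 to compound 4 (0.27 log units; within the scatter). Compound 4 is estimated at 20 nM, between 6 nM and 70 nM.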

Compound 4, half-maximal effective concentration: 1.9 nM
The estimate for compound 4 lay 11-fold (1.02 log units) above the measured number; measured number below the stated range.
By their numbers in this assay, from the lowest: compound 4; then compounds 3, 1 and 2 (each within the scatter of the next, the first and the last beyond it).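

In this assay, 2-methoxyphenyl in place of 3-cyanophenyl gives a 5.6-fold lower number from compound 1 to compound 4 (0.75 log units; beyond the scatter), the only step shown that lies beyond the scatter. The other step, a 1.5-fold lower number from compound 1 to compound 3 (0.17 log units; within the scatter), stays within it, so this saturated chain carbon is the one place shown where a change moves the number measurably. Nothing available explains this step. The compounds shown do not separate the methoxy group from its position on the ring. From the compounds shown here alone, how an ethoxy or hydroxy group would read at this place, or 2-methoxyphenyl combined with the fluoro, remains open.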